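The compounds below may be only part of what the source reports. "The series", "measured", "known", "first", "only" and "open" are said of these compounds alone.

Measured compounds:
Compound 1 `COCCNC(=O)[C@@H]1CC[C@H](Nc2ncc3c(Br)nn(-c4ccc5ncccc5c4)c3n2)C1` gives 923 nM in an assay on isolated protein for inhibition of eIF-2-alpha kinase GCN2 (Homo sapiens); on this read-out lower numbers stand for stronger inhibition and higher numbers for weaker inhibition.
Compound 2 `COCCNC(=O)[C@@H]1CC[C@@H](Nc2ncc3c(Br)nn(-c4ccc5ncccc5c4)c3n2)C1` gives 5 nM in this assay.

Compound 2 stands lowest of the two numbers shown. Its nearest neighbour is compound 1, and the step of a 180-fold lower number from compound 1 to compound 2 (2.27 log units; beyond the scatter) lies between them, a large one. Within the data shown here, the only evidence bearing on that step is the fact that compounds 1 and 2 differ only in the configuration as drawn, so the difference in this assay is tied to the drawn configuration at the saturated ring carbon and to nothing else.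

Compound 3 `COCc1noc([C@@H]2CC[C@@H](Nc3ncc4c(Br)nn(-c5ccc6ncccc6c5)c4n3)C2)n1` has not yet been measured. Set against compound 2 it shows (a group of 8 heavy atoms (4 carbon, 2 nitrogen, 2 oxygen; one five-membered aromatic ring with 3 hetero atoms) in place of a group of 7 heavy atoms (4 carbon, 1 nitrogen, 2 oxygen; no ring), on a saturated ring carbon). Among the measured compounds shown here, no measured step bears on this exchange: the single step on record concerns configuration alone and leaves the amide untouched, so there is no prior reading of what replacing the (2-methoxyethyl)carbamoyl group by the five-membered aromatic ring does in this assay. The expectation therefore rests on compound 2 alone, with a wide margin for either direction. The expected change is a 2.4-fold higher number from compound 2 to compound 3 (0.38 log units; beyond the scatter), a moderate step upward. Compound 3 is thus estimated to give 12 nM in this assay, within a range from 3 nM to 50 nM.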

Compound 3, half-maximal inhibitory concentration: 106 nM
For compound 3 the middle estimate is 8.8-fold (0.95 log units) below the measured one; the measured number lies above the stated range.
By their numbers in this assay, from the lowest: compound 2; then compound 3; then compound 1.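

Replacing the (2-methoxyethyl)carbamoyl group with a five-membered aromatic ring bearing a methoxymethyl substituent gives a 21-fold higher number from compound 2 to compound 3 (1.33 log units; beyond the scatter) in this assay, which shows that the read-out at this saturated ring carbon depends on the group it carries as well as on the drawn configuration, the only variable in the earlier pair. The exchange alters several things at once: the leaving group has 1 hydrogen-bond donor, 2 hydrogen-bond acceptors and no ring, whereas the entering group has 0 hydrogen-bond donors, 4 hydrogen-bond acceptors and one five-membered aromatic ring with 3 hetero atoms. Nothing on record bears on why this exchange produces a step of this size.

With all of these features changing together, the compounds shown cannot assign the step to the loss of the donor, the gain in acceptors or the presence of the ring. From the compounds shown here alone, it also remains open where a tertiary amide with no amide hydrogen, a carboxylic acid or a primary amine on this carbon would fall relative to compound 2 and compound 3 in this assay.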